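Hydroxy in place of methylsulfanyl on the oxazolidinone amide

The source may report more compounds than this note shows. Statements on the series, on what has been measured and on what is new or still open speak of the compounds shown alone.

Compound 1 `O=C(CCCCCc1ccc(I)cc1)N1CCOC1=O`: in an assay on HEK293 cells for inhibition of N-acylethanolamine-hydrolyzing acid amidase (Rattus norvegicus), read by LC-MS, with a stated time of 30 min (a lower number here means a stronger inhibitor, a higher number a weaker inhibitor), compound 1 gives > 20000 nM, which is a limit of the assay.
Compound 2 `CSc1ccc(CCCCCC(=O)N2CCOC2=O)cc1`: in this assay compound 2 gives > 20000 nM, again a limit of the assay.

For the measured compounds named here, compound 2 thus stands at the limit of this assay rather than at a number, and the only other value shown for its core is the same limit, so that the limit of > 20000 nM in this assay, at which 2 of the 2 values shown sit, is the whole of the evidence. Going by the values given here, the one measured step, a step that the two limits leave unreadable from compound 1 to compound 2, is unreadable because both ends are limits.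

Compound 3 `O=C(CCCCCc1ccc(O)cc1)N1CCOC1=O` differs from compound 2 by hydroxy in place of methylsulfanyl on an aromatic carbon. Among the compounds with values here, no measured step bears readably on this change, since the step from compound 1 to compound 2 gave no size. Within the data shown here, compound 2 lies at the limit, and no measured step shows that a change at this position moves the value out of that region. Compound 3 is therefore expected to give about 15000 nM in this assay, with a range from 3000 nM to 60000 nM. That estimate means an expected step of an at least 1.3-fold lower number from compound 2 to compound 3 (0.12 log units; that floor lies within the scatter), and it rests on compound 2 sitting at > 20000 nM.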

Compound 3, half-maximal inhibitory concentration: 61 nM
For compound 3 the middle estimate is 250-fold (2.39 log units) above the measured one, and the stated range ends above it.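

Compound 3 is the only compound shown that gives a number in this assay, and it shows that the group on the aromatic carbon para to a large group can decide the read-out: hydroxy in place of methylsulfanyl gives an at least 320-fold lower number from compound 2 to compound 3 (2.51 log units; beyond the scatter), and hydroxy in place of iodo gives an at least 320-fold lower number from compound 1 to compound 3 (2.51 log units; beyond the scatter). Both steps start from a limit, so their sizes are floors, while the step between compound 1 and compound 2 cannot be read. The earlier compounds had shown no change at this position at all, only a limit shared by both: the limit of > 20000 nM in this assay, at which 2 of the 3 values shown sit.

The compounds shown leave open whether the hydrogen-bond donor that hydroxy brings is what matters here, or whether other groups at this place would serve as well, a question that methoxy, which has an oxygen but no such donor, or an amine, which has a donor of its own, would help to settle. They also leave open whether a step of this size would persist with a longer chain on the shared core.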